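Long chain versus hydroxymethyl in a small series

The compounds below may be only part of what the source reports. "The series", "measured", "known", "first", "only" and "open" are said of these compounds alone.

Values in a functional assay on HCT-116 cells (Homo sapiens) for antiproliferative activity, read by MTT assay, with a stated time of 48 h; on this read-out lower numbers stand for stronger inhibition and higher numbers for weaker inhibition:
- compound 1 `CCC(CCO)n1cnc2c(Cl)ncnc21` gives > 50000 nM, a limit of the assay and not a number
- compound 2 `CCCC(CCO)n1cnc2c(Cl)ncnc21` gives > 50000 nM, a limit of the assay and not a number
- compound 3 `CCCCCCCC(CCO)n1cnc2c(Cl)ncnc21` gives 4160 nM

Among the measured compounds shown here, compound 3 at 4160 nM holds the only true number. The other two values are limits: the limit of > 50000 nM in this assay, at which 2 of the 3 values shown sit.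

Next in line is compound 4 `OCCC(CO)n1cnc2c(Cl)ncnc21`. Its difference from compound 3 is hydroxy in place of hexyl on a saturated chain carbon, two bonds along the chain from an aromatic nitrogen. In words, hydroxy stands in place of hexyl on a saturated chain carbon, two bonds along the chain from an aromatic nitrogen. Cut one bond further out, the same difference reads heptyl to hydroxymethyl.

For the measured compounds named here, two measured steps bear on this change: an at least 12-fold lower number from compound 1 to compound 3 (1.07 log units; beyond the scatter) and an at least 12-fold lower number from compound 2 to compound 3 (1.07 log units; beyond the scatter). Both are large, and both come with a longer chain, pentyl and butyl in place of hydrogen. The third step, a step that the two limits leave unreadable from compound 1 to compound 2, gives no usable size. Compound 4 loses the long chain, so the gain seen on reaching compound 3 is expected to be lost, and a large step to a higher number is expected in this assay. The estimated step is a 12-fold higher number from compound 3 to compound 4 (1.08 log units; beyond the scatter). For compound 4 the expected value is 50000 nM, with an estimated range from 20000 nM to 100000 nM. A report as a limit only is the likely outcome.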

Compound 4, half-maximal inhibitory concentration: > 50000 nM
Compound 4 ended at the assay's limit; the forecaster's own chance of this, stated with the estimate: 75%; the middle value sits exactly at the limit.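

In this assay, among the compounds shown here, hydroxy in place of hexyl on a saturated chain carbon, two bonds along the chain from an aromatic nitrogen, gives an at least 12-fold higher number from compound 3 to compound 4 (1.07 log units; beyond the scatter) and removes the only measurable number. Read one bond further out, as heptyl to hydroxymethyl, this is the first comparison in which the long chain gives way to a group carrying a hydroxy rather than to a shorter carbon chain, and the hydroxymethyl does not keep a measurable number in this assay. The steps from compound 1 and from compound 2 to compound 4 cannot be read, so these three compounds cannot be ranked against one another: the limit of > 50000 nM in this assay, at which 3 of the 4 values shown sit.

The compounds shown leave open whether the loss follows the departure of the hexyl or the arrival of the hydroxy, and how a longer chain, an amine or a carboxylic acid at this place would read in this assay. Also open, from the compounds shown here alone, is the chain length at which a measurable number first appears, as compound 3 alone gives one so far.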